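The compounds below may be only part of what the source reports. "The series", "measured", "known", "first", "only" and "open" are said of these compounds alone.

Going by the values given here, compound 1 `COc1cc(-c2cc(/C=C/C(=O)c3ccc(N)cc3)[nH]n2)cc(OC)c1OC` gives 76% in a functional assay on A498 cells (Homo sapiens) for cytotoxicity, read by sulforhodamine B assay, with a stated time of 48 h, tested at 1 uM (a higher number here means a weaker effect of the compound at the concentration tested, a lower number a stronger effect), the second highest of the three numbers so far, with compound 2 `COc1cc(-c2cc(/C=C/C(=O)c3ccc(Cl)c(Cl)c3)[nH]n2)cc(OC)c1OC` nearest at 73% and compound 3 `COc1ccc(C(=O)/C=C/c2cc(-c3cc(OC)c(OC)c(OC)c3)n[nH]2)cc1` furthest at 84%. Compound 4 `COc1cc(-c2cc(/C=C/C(=O)c3ccc(F)c(F)c3)[nH]n2)cc(OC)c1OC` awaits measurement; it differs from compound 1 by 3,4-difluorophenyl in place of 4-aminophenyl on a carbonyl carbon. The closest measured step is a number 3 percentage points lower from compound 1 to compound 2 (within the scatter), a related exchange on a carbonyl carbon. The step of a number 8 percentage points higher from compound 1 to compound 3 (within the scatter) also lies within the scatter, and a number 11 percentage points higher from compound 2 to compound 3 (beyond the scatter) is the only one beyond it. On this basis a step of a number 2 percentage points lower from compound 1 to compound 4 (within the scatter) is expected, that is, nothing beyond the scatter. Compound 4 is therefore estimated at 74%, with a range from 62% to 86%.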

Compound 4, a percentage reported as activity, at one concentration (the size of the read-out at that concentration, not a potency): 81%
The estimate for compound 4 lay 7 percentage points below the measured number; the measured number falls inside the stated range.
By their numbers in this assay, from the lowest: compounds 2, 1, 4 and 3 (each within the scatter of the next, the first and the last beyond it).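

With 3,4-difluorophenyl on the carbonyl carbon, this assay shows no step beyond the scatter from any of the three earlier compounds: a number 5 percentage points higher from compound 1 to compound 4 (within the scatter), a number 3 percentage points lower from compound 3 to compound 4 (within the scatter), and a number 8 percentage points higher from compound 2 to compound 4 (within the scatter). Replacing 4-aminophenyl, which carries a hydrogen-bond donor, and replacing 3,4-dichlorophenyl, with fluorine in place of chlorine, both stay within the scatter. No measurement shown here accounts for these small steps.

Going by these compounds, it remains open whether a non-aromatic group on this carbonyl carbon, such as cyclohexyl or a longer alkyl chain, would give a step beyond the scatter. The same holds for a phenyl ring bearing a carboxylic acid.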